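The source may hold more compounds than are shown below. What is called first, only, known or untested is meant among the compounds shown, and "the series" means these compounds.

- compound 1 `O=C(c1ccccc1)c1cc(Br)ccc1OCCn1ccc(=O)[nH]c1=O`: > 301000 nM
- compound 2 `O=C(c1ccccc1)c1cc(Cl)ccc1OCCn1ccc(=O)[nH]c1=O`: > 337000 nM
- compound 3 `O=C(c1cc(Cl)cc(Cl)c1)c1cc(Cl)ccc1OCCn1ccc(=O)[nH]c1=O`: > 284000 nM

All three compounds were tested in an ADME assay on MT4 cells (Homo sapiens) for cytotoxicity, read by MTT assay, with a stated time of 4 days (on this read-out higher numbers stand for lower toxicity in this test and lower numbers for higher toxicity in this test), and each result is a limit, not a number. Compound 2 stands at > 337000 nM, which is only a limit. The other two results are limits as well, so compound 2 has no readable rank among them.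

Compound 4 `O=C(c1ccccc1)c1cc(F)ccc1OCCn1ccc(=O)[nH]c1=O` differs from compound 2 by a single change: fluoro in place of chloro on an aromatic carbon. Fluoro takes the place of chloro on an aromatic carbon. The closest measured change is chloro in place of bromo on that same carbon, and it gives a step that the two limits leave unreadable from compound 1 to compound 2. The other measured change, 3,5-dichlorophenyl in place of phenyl on a carbonyl carbon, gives a step that the two limits leave unreadable from compound 2 to compound 3. Neither step has a size that can be read, so neither offers a measured shift to carry over. All three compounds nevertheless ended at a limit, so no step beyond the scatter is expected in this assay, and another limit is the likeliest result. The estimate for this change is a step that the limit leaves unreadable from compound 2 to compound 4. Compound 4 is expected at 350000 nM, with an estimated range from 200000 nM to 450000 nM.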

Compound 4, half-maximal cytotoxic concentration: > 353000 nM
Compound 4: no number, only a limit; the forecaster's own chance of this, stated with the estimate: 85%; middle value at least 1.0-fold (0.00 log units) away from the limit.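

In this assay compound 4 gives > 353000 nM, which is a limit and not a number. Compound 1 and compound 2 also have only limits, so neither step to compound 4 can be read. The compounds shown leave open the concentration at which any of them would harm these cells, and whether fluoro, chloro or bromo on that aromatic carbon makes any difference.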